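Fluorinated five-membered ring in place of pyrazole on the core

The source may hold more compounds than are shown below. What is called first, only, known or untested is meant among the compounds shown, and "the series" means these compounds.

Compound 1 `Oc1ccc(Cn2cccn2)c2cccnc12` — 700 nM
Compound 2 `Cc1cc2ncn(Cc3ccc(O)c4ncccc34)c2cc1C` — "not determined" (no result reported)
Compound 3 `CC(C)(C)OC(=O)Oc1ccc(Cn2c(-c3cscn3)nc3ccccc32)c2cccnc12` — "not determined" (no result reported)

Three compounds were taken into a functional assay on MM1.S cells (Homo sapiens) for antiproliferative activity, read by luminescence, with a stated time of 72 h; a higher number here means a weaker inhibitor, a lower number a stronger inhibitor. In this assay compound 1 gives 700 nM. For compound 2 the entry reads "not determined" (no result reported), and for compound 3 it likewise reads "not determined" (no result reported), so neither adds a number. For the measured compounds named here, compound 1 therefore stands alone: it holds the only value shown, and no pair of measured compounds exists whose step could be followed in this assay.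

Compound 4 `Oc1ccc(Cn2cnc(F)c2)c2cccnc12` has not yet been measured. It differs from compound 1 in one place: a group of 6 heavy atoms (3 carbon, 2 nitrogen, 1 fluorine; one five-membered aromatic ring with 2 hetero atoms) in place of a group of 5 heavy atoms (3 carbon, 2 nitrogen; one five-membered aromatic ring with 2 hetero atoms), on a saturated chain carbon bound to an aromatic carbon. The group that enters and the group that leaves each hold one five-membered aromatic ring with 2 hetero atoms, 0 hydrogen-bond donors and 2 hydrogen-bond acceptors, the entering group adding 1 fluorine. Going by the values given here, no measured pair tells what such an exchange does here, so the expectation rests on the modest size of the change alone. In this assay compound 4 is expected to give 800 nM, within a range from 250 nM to 2500 nM. This estimate means an expected step of a 1.1-fold higher number from compound 1 to compound 4 (0.06 log units; within the scatter), which is expected to stay within the usual scatter rather than mark a clear change in either direction.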

Compound 4, half-maximal inhibitory concentration: 1200 nM
The estimate for compound 4 lay 1.5-fold (0.18 log units) below the measured number; measured number inside the range.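

In this assay, for the compounds shown here, replacing the 1H-pyrazol-1-yl group of compound 1 with the fluorinated five-membered ring on the saturated chain carbon gives a 1.7-fold higher number from compound 1 to compound 4 (0.23 log units; within the scatter), the first step that can be followed, and compound 1 and compound 4 cannot be told apart on this evidence. At this position, then, one five-membered aromatic ring with 2 hetero atoms can stand in for another, with a fluorine added, and the antiproliferative read-out stays within the usual scatter of repeated measurements. Nothing shown explains this outcome or separates the contribution of the fluorine from that of the altered ring.

Going by these compounds alone, with only this one step in hand, it remains open how the position would respond to a larger departure, such as a morpholine, an amine or a carboxylic acid on the chain carbon, or to a chlorine or a methyl in place of the fluorine. The entries for compound 2 and compound 3 hold no number, so they add nothing on the groups they carry at this position.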